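The compounds below may be only part of what the source reports. "The series", "measured", "known", "first", "only" and "open" are said of these compounds alone.

Measured so far in a functional assay on MDA-MB-231 cells (Homo sapiens) for cytotoxicity, read by MTT assay, with a stated time of 72 h; on this read-out higher numbers stand for weaker inhibition and lower numbers for stronger inhibition: compound 1 `COc1cc2c(Oc3ccc(NC(=O)N/N=C/c4ccc([N+](=O)[O-])cc4)cc3F)ccnc2cc1OCCCN1CCCC1` gives 970 nM; compound 2 `COc1cc2c(Oc3ccc(NC(=O)N/N=C/c4ccc(C(F)(F)F)cc4)cc3F)ccnc2cc1OCCCN1CCCC1` gives 1800 nM; compound 3 `COc1cc2c(Oc3ccc(NC(=O)N/N=C/c4ccc(N(C)C)cc4)cc3F)ccnc2cc1OCCCN1CCCCC1` gives 1400 nM.

Compound 2 stands highest of the three numbers, yet both gaps sit within the scatter: a 1.9-fold higher number from compound 1 to compound 2 (0.27 log units; within the scatter), and compound 3 differs from compound 2 in more than one place, so only its value is compared. Compound 4 `COc1cc2c(Oc3ccc(NC(=O)N/N=C/c4ccc(C(F)(F)F)cc4)cc3F)ccnc2cc1OCCCN1CCC(C)CC1` is not yet measured; it carries 4-methylpiperidin-1-yl in place of pyrrolidin-1-yl on a saturated chain carbon, three bonds along the chain from an oxygen on an aromatic ring. For the measured compounds named here, no measured step touches this change; the only step known, a 1.9-fold higher number from compound 1 to compound 2 (0.27 log units; within the scatter), concerns the aryl substituent and reads within the scatter. With nothing bearing on the ring change, no step beyond the scatter is expected, no change at the digits printed from compound 2 to compound 4 (within the scatter). Compound 4 is therefore estimated at 1800 nM, range 700 nM to 4500 nM in this assay.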

Compound 4, half-maximal inhibitory concentration: 1300 nM
Compound 4: middle estimate off by 1.4-fold (0.14 log units), on the high side, and the stated range covers the measured number.
By their numbers in this assay, from the lowest: compounds 1, 4, 3 and 2 (each within the scatter of the next).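

First reading at this place on the chain: in this assay, 4-methylpiperidin-1-yl in place of pyrrolidin-1-yl gives a 1.4-fold lower number from compound 2 to compound 4 (0.14 log units; within the scatter), so this exchange, with two more heavy atoms, does not move the number beyond the scatter in the trifluoromethyl pair. Nothing available accounts for the size of this step.

Ring size and the methyl group change together here, so their separate contributions remain unresolved. Also open, going by these compounds, is whether a morpholine ring or a longer chain at this place would give a step beyond the scatter.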